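This account rests on a few compounds, and the source may have more. Where it says the series, first, only, none or still open, it means among the compounds named here.

Compound 1, `N#Cc1c(N)nc(SCc2cccc(C(N)=O)c2)c(C#N)c1-c1ccc(OCC2CC2)cc1`, is the anchor of this comparison. In an assay on CHO cells for displacement of a labelled ligand from adenosine receptor A1 (Homo sapiens), read by scintillation counting, with a stated time of 90 min (on this read-out higher numbers stand for weaker inhibition and lower numbers for stronger inhibition), compound 1 gives 83 nM, the lowest of the three numbers in hand. Compound 2, `CC(C)COc1ccc(-c2c(C#N)c(N)nc(SCC(N)=O)c2C#N)cc1`, gives 603 nM, and compound 3, `CCOc1ccc(-c2c(C#N)c(N)nc(SCC(N)=O)c2C#N)cc1`, gives 345 nM; both lie well above compound 1, and both carry a different group on the sulfur side as well as a different ether, so neither provides a single-change step to compound 1.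

Compound 4, `N#Cc1c(N)nc(SCC2=NCCN2)c(C#N)c1-c1ccc(OCC2CC2)cc1`, is the next compound. It differs from compound 1 as follows: a group of 5 heavy atoms (3 carbon, 2 nitrogen; one five-membered non-aromatic ring with 2 hetero atoms) in place of a group of 9 heavy atoms (7 carbon, 1 nitrogen, 1 oxygen; one six-membered aromatic ring of carbon only), on a saturated chain carbon bound to a sulfur.

Among the measured compounds shown here, the only measured single-change step, a 1.7-fold lower number from compound 2 to compound 3 (0.24 log units; within the scatter), concerns the ether substituent and not the sulfur side, so it says little about the present change. For the measured compounds named here, no measured pair shows what swapping the group on the saturated chain carbon bound to a sulfur does to this assay, and the entering group appears in no measured compound. The direction of the step is therefore open, and a change of this size, beyond the scatter in either direction, would be no surprise.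

The number for compound 4 in this assay is estimated at 150 nM, with a range of 40 nM to 600 nM, which means an expected step of a 1.8-fold higher number from compound 1 to compound 4 (0.26 log units; within the scatter).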

Compound 4, inhibition constant: 483 nM
Beside the measured number, compound 4's estimate is 3.2-fold (0.51 log units) below it; measured number inside the range.
By their numbers in this assay, from the lowest: compound 1; then compounds 3, 4 and 2 (each within the scatter of the next).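

In this assay, replacing the 3-carbamoylphenyl group with the smaller five-membered non-aromatic ring, on a saturated chain carbon bound to a sulfur, gives a 5.8-fold higher number from compound 1 to compound 4 (0.76 log units; beyond the scatter) with the rest of the molecule unchanged. Among the compounds shown here, this is the first single-change step at this place, and it shows that the group held there matters in this assay, since the step lies beyond the usual scatter of repeated measurements. It also gives the step a direction for this one pair, with the 3-carbamoylphenyl group on the side of the lower number and so of the stronger inhibition, but nothing available here accounts for that difference.

The step changes the ring type, the ring size and the carbamoyl group all at once, so the compounds shown cannot say which of these differences carries the effect. Going by these compounds, a plain phenyl group at this place would separate the aromatic ring from the carbamoyl group, and how a carboxylic acid or an amine on that ring would compare also remains open.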